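The source may hold more compounds than are shown below. What is called first, only, known or untested is meant among the compounds shown, and "the series" means these compounds.

Of the compounds shown here, two built on one shared core have so far been measured in a functional assay on HCT-116 cells (Homo sapiens) for cytotoxicity, read by MTT assay, with a stated time of 24 h; on this read-out higher numbers stand for weaker inhibition and lower numbers for stronger inhibition. Compound 1 `COc1cccc(-n2cc(COc3c(/C=C\C(=O)O)ccc(OC)c3CC=C(C)C)nn2)c1` gives 21600 nM, and compound 2 `COc1ccc(/C=C\C(=O)O)c(OCc2cn(-c3ccccc3)nn2)c1CC=C(C)C` gives 26000 nM. These two numbers lie within the scatter of each other, so compound 2 stands level with compound 1 and neither can be ranked above the other.

Compound 3 `COc1ccc(/C=C\C(=O)O)c(OCc2cn(-c3cccnc3Cl)nn2)c1CC=C(C)C` keeps the core of compound 2 and has 2-chloropyridin-3-yl in place of phenyl on an aromatic nitrogen. Going by the values given here, only one measured step bears on this change, and it alters the same group, with hydrogen in place of methoxy on an aromatic carbon. That step is a 1.2-fold higher number from compound 1 to compound 2 (0.08 log units; within the scatter), which stays within the scatter. Among the compounds with values here, this is thin evidence, since no measured compound carries chlorine or a ring nitrogen in this group, and the data give no direction for the change.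

The expected move in this assay is therefore small, and the estimated step is a 1.2-fold lower number from compound 2 to compound 3 (0.07 log units; within the scatter), none beyond the scatter. The estimate for compound 3 is 22000 nM, with an expected range from 9000 nM to 50000 nM.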

Compound 3, half-maximal inhibitory concentration: 23000 nM
The estimate for compound 3 lay 1.0-fold (0.02 log units) below the measured number, and the stated range covers the measured number.
By their numbers in this assay, from the lowest: compounds 1, 3 and 2 (each within the scatter of the next).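

Placing 2-chloropyridin-3-yl on the aromatic nitrogen in place of phenyl brings a ring nitrogen and a chlorine into this group for the first time, and in this assay the result is a 1.1-fold lower number from compound 2 to compound 3 (0.05 log units; within the scatter) and no ranking of the two compounds follows. Set against the methoxy-bearing ring, 2-chloropyridin-3-yl in place of 3-methoxyphenyl gives a 1.1-fold higher number from compound 1 to compound 3 (0.03 log units; within the scatter) so all three compounds stand level, and at this position three differently substituted six-membered aromatic rings cannot be told apart by this read-out. No further measurement is available to bear on this level result.

As far as these compounds go, the ring nitrogen and the chlorine arrive together in compound 3, so the part played by each alone stays open, and a pyridin-3-yl or a 2-chlorophenyl group would be needed to separate them. Also open, from the compounds shown here alone, is whether a group of another kind on this aromatic nitrogen, such as a cyclohexyl ring, a benzyl group or an n-butyl chain, would move the number beyond the scatter.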